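From Methyl to Ethyl in a Cytotoxicity Series

A few compounds are considered here, and "the series" means these few. Any claim that something is new, unique, unknown or untested is made for them only; others in the source may bear on it.

In an ADME assay on MT4 cells (Homo sapiens) for cytotoxicity, read by MTT assay (a higher number here means that more compound is tolerated, a lower number that less compound is tolerated), compound 3 `Cc1c(Cc2c(F)cccc2Cl)nc(SCC(=O)c2ccc(F)cc2)[nH]c1=O` gives > 59000 nM, which is a limit and not an exact number. Compound 2 `Cc1c(Cc2c(F)cccc2Cl)nc(SCC(=O)c2ccccc2)[nH]c1=O` gives > 12000 nM, also a limit. Among the measured compounds shown here, the only measured step, a step that the two limits leave unreadable from compound 2 to compound 3, therefore has no readable size, and it concerns a different change. Compound 4 `CCc1c(Cc2c(F)cccc2Cl)nc(SCC(=O)c2ccc(F)cc2)[nH]c1=O` differs from compound 3 by methyl in place of hydrogen on a saturated chain carbon bound to an aromatic carbon, so that methyl becomes ethyl. For the measured compounds named here, no measured step isolates this change. Compound 1 `CCc1c(Cc2c(Cl)cccc2Cl)nc(SCC(=O)c2ccc(F)cc2)[nH]c1=O`, which already carries the ethyl but also differs elsewhere, gives > 55000 nM, again a limit. All three measured compounds thus end in limits in this assay, and none gives an exact number to build on. With so little to go on, no shift beyond the usual scatter is expected. The expected step of an at least 1.0-fold lower number from compound 3 to compound 4 (0.01 log units; that floor lies within the scatter) is accordingly small, and the result may well be reported only as a limit again. For compound 4 the estimated value is 57000 nM, with an expected range from 20000 nM to 120000 nM.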

Compound 4, half-maximal cytotoxic concentration: > 57000 nM
Compound 4 was reported as a limit; the forecaster's own chance of this, stated with the estimate: 85%; the middle value lies on the limit itself.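

In this assay, compound 4 gives only a limit, as do compound 1 and compound 3, so the steps to compound 4 from compound 1 and from compound 3 cannot be read. The compounds shown leave open whether methyl to ethyl, or fluoro in place of chloro, shifts the tolerated concentration at all.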